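A few compounds are considered here, and "the series" means these few. Any claim that something is new, unique, unknown or untested is made for them only; others in the source may bear on it.

In a functional assay on FM3A cells (Mus musculus) for inhibition, read by cell counting, with a stated time of 2 days; a higher number here means a weaker inhibitor, a lower number a stronger inhibitor:
compound 1 `C=C(Br)C(=O)Nc1cccc(-c2cn3nc(-c4ccc(OC)c(OC)c4)sc3n2)c1` gives 110 nM
compound 2 `C=C(Br)C(=O)Nc1cccc(-c2cn3nc(-c4cccs4)sc3n2)c1` gives 370 nM
compound 3 `C=C(Br)C(=O)Nc1cccc(-c2cn3nc(Cc4ccccc4)sc3n2)c1` gives 3000 nM

Compound 3 stands highest of the three: a 27-fold higher number from compound 1 to compound 3 (1.44 log units; beyond the scatter) and an 8.1-fold higher number from compound 2 to compound 3 (0.91 log units; beyond the scatter), both beyond the scatter. Compound 4 `C=C(Br)C(=O)Nc1cccc(-c2cn3nc(-c4ccc(OC)cc4)sc3n2)c1` is the next step from compound 3: 4-methoxyphenyl in place of benzyl on an aromatic carbon. The relevant measured steps are a 27-fold higher number from compound 1 to compound 3 (1.44 log units; beyond the scatter), where an aromatic ring bearing methoxy groups on the same carbon gave the lowest number, and a 3.4-fold higher number from compound 1 to compound 2 (0.53 log units; beyond the scatter), which suggests the methoxy substitution matters less than having the aromatic ring directly attached. Reverting from benzyl to a methoxy-bearing aryl group should therefore bring a large drop, estimated as a 15-fold lower number from compound 3 to compound 4 (1.18 log units; beyond the scatter). For compound 4 the expected value is 200 nM, within a range of 80 nM to 600 nM.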

Compound 4, half-maximal inhibitory concentration: 890 nM
Compound 4: the middle estimate sits 4.5-fold (0.65 log units) below what was measured; the whole stated range lies below it.
By their numbers in this assay, from the lowest: compound 1; then compound 2; then compound 4; then compound 3.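

In this assay, 4-methoxyphenyl in place of benzyl gives a real but limited gain (a 3.4-fold lower number from compound 3 to compound 4 (0.53 log units; beyond the scatter)), and it does not match thiophen-2-yl (a 2.4-fold higher number from compound 2 to compound 4 (0.38 log units; beyond the scatter)). Direct attachment of a methoxy-bearing aryl ring is therefore not enough in itself at this aromatic carbon, and hydrogen in place of methoxy carries a larger penalty (an 8.1-fold higher number from compound 1 to compound 4 (0.91 log units; beyond the scatter)) than the opening steps implied. No measured evidence accounts for this difference.

Still open, from the compounds shown here alone, is how unsubstituted phenyl would compare here. Also open, going by these compounds, is whether an amine or a hydroxyl group could replace methoxy and retain the number of compound 1 (110 nM).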